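Methoxy on the Benzoyl Group: Compound 1 to Compound 4

The source may report more compounds than this note shows. Statements on the series, on what has been measured and on what is new or still open speak of the compounds shown alone.

Measured compounds:
Compound 1, `COc1ccc(/C=C/c2cc(OC)cc(OC)c2/C=C/C(=O)c2ccccc2)cc1`: 3.9 ug/mL
Compound 2, `COc1ccc(/C=C/c2cc(OC)cc(OC)c2/C=C/C(=O)c2ccccc2C)cc1`: 5.9 ug/mL
Compound 3, `COc1ccc(/C=C/c2cc(OC)cc(OC)c2/C=C/C(=O)c2ccc(F)cc2)cc1`: 6.6 ug/mL

In a functional assay on A549 cells (Homo sapiens) for antiproliferative activity, read by MTT assay, with a stated time of 48 h (on this read-out lower numbers stand for stronger inhibition and higher numbers for weaker inhibition), compound 1 has the lowest number of the three, but both others lie within the scatter of it: a 1.5-fold higher number from compound 1 to compound 2 (0.18 log units; within the scatter) and a 1.7-fold higher number from compound 1 to compound 3 (0.23 log units; within the scatter). Compound 4, `COc1ccc(/C=C/c2cc(OC)cc(OC)c2/C=C/C(=O)c2cccc(OC)c2)cc1`, differs from compound 1 by methoxy in place of hydrogen on an aromatic carbon. The two measured steps that bear on this change are the substitutions of the same benzoyl ring in compound 2 and compound 3, each a step within the scatter. For compound 4 a step of similar size, or none beyond the scatter, is therefore expected: a 1.2-fold higher number from compound 1 to compound 4 (0.09 log units; within the scatter). The estimated value for compound 4 is 4.8 ug/mL, with a range from 2.5 ug/mL to 9.5 ug/mL.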

Compound 4, half-maximal inhibitory concentration: 6.1 ug/mL
Estimate against measurement, compound 4: 1.3-fold (0.10 log units) below; low and high end bracket the measured number.
By their numbers in this assay, from the lowest: compounds 1, 2, 4 and 3 (each within the scatter of the next).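

In this assay, methoxy on the benzoyl ring gives a 1.6-fold higher number from compound 1 to compound 4 (0.19 log units; within the scatter), so a third substituent on this ring also stays within the scatter of the plain phenyl of compound 1. Against the other two substituted rings, the 3-methoxyphenyl group gives a 1.1-fold lower number from compound 3 to compound 4 (0.03 log units; within the scatter) and a 1.0-fold higher number from compound 2 to compound 4 (0.01 log units; within the scatter), so methoxy cannot be told apart from fluoro or methyl at this level of resolution. No evidence at hand bears on why the numbers stay so close. From the compounds shown here alone, whether an amine or a carboxylic acid on this ring would move the number beyond the scatter remains open.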